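Ring for Chain on the Weaker Mirror Image

A few compounds are considered here, and "the series" means these few. Any claim that something is new, unique, unknown or untested is made for them only; others in the source may bear on it.

Of the compounds shown here, three built on one shared core have been measured in an assay on isolated protein for inhibition of Rho-associated protein kinase 2 (Homo sapiens); on this read-out lower numbers stand for stronger inhibition and higher numbers for weaker inhibition. Compound 1 `CC(C)[C@H](N)C(=O)Nc1cc2cc[nH]c(=O)c2cc1Cl` gives 12 nM. Compound 2 `O=C(Nc1cc2cc[nH]c(=O)c2cc1Cl)[C@@H]1CCCN1` gives 35 nM. Compound 3 `CC(C)[C@@H](N)C(=O)Nc1cc2cc[nH]c(=O)c2cc1Cl` gives 240 nM, the highest number of the three and thus the weakest inhibitor in this small set. Compounds 1 and 3 are mirror images of each other, and a 20-fold higher number from compound 1 to compound 3 (1.30 log units; beyond the scatter) is the largest step seen here; it rests on (the fact that compounds 1 and 3 differ only in the configuration as drawn). The other two steps are smaller: a 2.9-fold higher number from compound 1 to compound 2 (0.46 log units; beyond the scatter) and a 6.9-fold higher number from compound 2 to compound 3 (0.84 log units; beyond the scatter).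

Compound 4 `O=C(Nc1cc2cc[nH]c(=O)c2cc1Cl)[C@H]1CCCN1` has not yet been measured. It differs from compound 3 in one place: pyrrolidin-2-yl in place of 1-amino-2-methylpropyl on a carbonyl carbon. The same exchange of pyrrolidin-2-yl for 1-amino-2-methylpropyl on a carbonyl carbon has been seen once already, going from compound 1 to compound 2, where it cost a modest amount. As far as these compounds go, whether the exchange behaves the same on the other configuration is unknown from the measured compounds, so the expectation is wider than that single step. Compound 4 is expected to show a 2.7-fold higher number from compound 3 to compound 4 (0.43 log units; beyond the scatter) in this assay. Compound 4 is therefore estimated at 650 nM, with a likely range from 150 nM to 2800 nM.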

Compound 4, half-maximal inhibitory concentration: 130 nM
Estimate against measurement, compound 4: 5.0-fold (0.70 log units) above; the whole stated range lies above it.
By their numbers in this assay, from the lowest: compound 1; then compound 2; then compounds 4 and 3 (each within the scatter of the next).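

In this assay, exchanging the chain for the ring on the weaker configuration gives a 1.8-fold lower number from compound 3 to compound 4 (0.27 log units; within the scatter), unlike the same exchange on the other configuration, which gave a 2.9-fold higher number from compound 1 to compound 2 (0.46 log units; beyond the scatter). So the effect of this exchange depends on how the carbon attached to the carbonyl is drawn, and the ring pair shows that configuration matters for more than the chain, with a 3.7-fold higher number from compound 2 to compound 4 (0.57 log units; beyond the scatter) alongside the chain pair's a 20-fold higher number from compound 1 to compound 3 (1.30 log units; beyond the scatter), and in both pairs the form drawn S carries the lower number; the ring step can be laid to configuration alone: the fact that compounds 2 and 4 differ only in the configuration as drawn. The step that joins both changes, ring for chain and the other configuration, is an 11-fold higher number from compound 1 to compound 4 (1.03 log units; beyond the scatter).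

The compounds shown leave open whether a six-membered piperidin-2-yl ring, or a hydroxyl group in place of the amine, would keep this preference for one configuration. They also cannot say why configuration counts at this carbon, only that it does in both the chain pair and the ring pair.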